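Compound 3: a larger aromatic group in place of pyrazolyl

This account rests on a few compounds, and the source may have more. Where it says the series, first, only, none or still open, it means among the compounds named here.

In an ADME assay on a cell-free system (plasma, Homo sapiens) for protein binding, with Plasma (Rattus norvegicus) as the target, compound 1 `O=C(O)c1cn(Cc2ccc(-n3cccn3)cc2)c2cccc(F)c2c1=O` gives 89.8%. Going by the values given here, its only measured neighbour is compound 2 `Cc1ccn(-c2ccc(Cn3cc(C(=O)O)c(=O)c4c(F)cccc43)cc2)n1`, which gives 92.3%, and these two values lie within the scatter of each other. Compound 3 `O=C(O)c1cn(Cc2ccc(-n3ccc4cnccc43)cc2)c2cccc(F)c2c1=O` has not yet been measured. It differs from compound 1 in one place: a group of 9 heavy atoms (7 carbon, 2 nitrogen; one five-membered aromatic ring with 1 hetero atom, one six-membered aromatic ring with 1 hetero atom) in place of a group of 5 heavy atoms (3 carbon, 2 nitrogen; one five-membered aromatic ring with 2 hetero atoms), on an aromatic carbon. The 1H-pyrazol-1-yl group leaves, and a larger group with one five-membered and one six-membered aromatic ring enters, on an aromatic carbon of the same six-membered ring of carbon only.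

Among the compounds with values here, one measured step bears on this change: a 1.3-fold lower unbound fraction from compound 1 to compound 2 (0.12 log units; within the scatter), with methyl in place of hydrogen on an aromatic carbon. Within the data shown here, that is a far smaller change than the one leading to compound 3, so it offers only a weak guide to direction. Among the measured compounds shown here, no measured compound carries the entering group, which leaves the size of the step uncertain. The expected result in this assay is a modest move the same way, estimated as a 1.5-fold lower unbound fraction from compound 1 to compound 3 (0.16 log units; within the scatter). For compound 3 the estimated value is 93%, with an expected range from 85% to 97.5%.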

Compound 3, plasma protein binding: 98.2%
Estimate against measurement, compound 3: 3.9-fold (0.59 log units) (unbound fraction) above, outside the stated range (above it).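

In this assay, going by these compounds alone, the position on the six-membered aromatic ring of carbon only now proves able to carry a step beyond the scatter: the exchange of 1H-pyrazol-1-yl for the larger group gives a 5.7-fold lower unbound fraction from compound 1 to compound 3 (0.75 log units; beyond the scatter) and, set against the methylated group, gives a 4.3-fold lower unbound fraction from compound 2 to compound 3 (0.63 log units; beyond the scatter) in the same direction, whereas the only earlier step, a 1.3-fold lower unbound fraction from compound 1 to compound 2 (0.12 log units; within the scatter) stayed within the scatter. This happens with no difference between the leaving and entering groups in hydrogen-bond donors, hydrogen-bond acceptors or net charge; what differs is the number of heavy atoms and the added six-membered aromatic ring. Nothing at hand accounts for this result.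

The compounds shown leave open whether the step follows the size of the entering group, its second aromatic ring or the place of its nitrogen atoms, since all of these change together in compound 3. A plain phenyl group or a morpholin-4-yl group on the same aromatic carbon would be needed to tell whether a group without this fused pair of aromatic rings can reach the same level of binding.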